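Chloro for fluoro, made twice across two cores

A few compounds are considered here, and "the series" means these few. Any claim that something is new, unique, unknown or untested is made for them only; others in the source may bear on it.

Measured in a functional assay on HT-29 cells (Homo sapiens) for antiproliferative activity, read by MTT assay, with a stated time of 48 h; a higher number here means a weaker inhibitor, a lower number a stronger inhibitor:
compound 1 `O=C(/C=C\Nc1ccc(F)cc1)c1cn(-c2ccccc2)nc1-c1ccccc1` gives 6870 nM
compound 2 `O=C(/C=C\Nc1ccc(Cl)cc1)c1cn(-c2ccccc2)nc1-c1ccccc1` gives 3610 nM
compound 3 `COc1cc(N/C=C\C(=O)c2cn(-c3ccccc3)nc2-c2ccc(F)cc2)cc(OC)c1OC` gives 7770 nM

Compound 1 and compound 2 differ in one place, (chloro in place of fluoro on an aromatic carbon). This change gave a 1.9-fold lower number from compound 1 to compound 2 (0.28 log units; within the scatter), a step that stays within the scatter of the method.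

Compound 3 sits on a different core; the difference between the core of compound 1 and the core of compound 3 is not broken down here. Compound 3 and compound 1 are within the scatter of each other, so no order between them is claimed. Compound 3 and compound 2 are apart by more than the scatter.

Compound 4 `COc1cc(N/C=C\C(=O)c2cn(-c3ccccc3)nc2-c2ccc(Cl)cc2)cc(OC)c1OC` has not yet been measured in this assay. It differs from compound 3 in one place, (chloro in place of fluoro on an aromatic carbon). The place is described in the same words as for the pair of compound 1 and compound 2, so this is the same change, occurring twice in all among the compounds here.

Going by the values given here, for compound 4 the step from its parent is expected to be small, about a 1.7-fold lower number from compound 3 to compound 4 (0.24 log units; within the scatter), in line with the only measured instance. That expectation rests on compound 1 and compound 2, where the same change gave a 1.9-fold lower number from compound 1 to compound 2 (0.28 log units; within the scatter). Among the compounds with values here, only one prior example exists, so the range is kept wide. Compound 4 is therefore estimated at 4500 nM in this assay, expected to fall between 2000 nM and 10000 nM.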

Compound 4, half-maximal inhibitory concentration: 12700 nM
Estimate against measurement, compound 4: 2.8-fold (0.45 log units) below, outside the stated range (above it).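

In this assay, chloro in place of fluoro gave a 1.6-fold higher number from compound 3 to compound 4 (0.21 log units; within the scatter), a step that taken alone does not stand out from the scatter of the method. Set beside the earlier instance, the step runs the other way, and the gap between the two is larger than the scatter allows: the same change on two cores in this assay, a 1.9-fold lower number (0.28 log units; within the scatter) from compound 1 to compound 2 and a 1.6-fold higher number (0.21 log units; within the scatter) from compound 3 to compound 4, 3.1-fold (0.49 log units) apart, beyond the scatter of two such steps. This shows that, on these two pairs, the change does not carry over from one core to another as a fixed step, so a step read on one core is a poor guide to the next; it does not show that chloro helps on one core and harms on the other, since neither step alone is beyond the scatter, and two pairs cannot tell which part of the cores goes with the gap.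

The compounds shown hold only fluoro and chloro at this place, so it remains open how a larger halogen such as bromo, or an amine or a carboxylic acid, would read on either core. Going by these compounds, it also remains open whether a third core would follow the step seen on the first pair, the step seen on the second, or neither.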